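The source may report more compounds than this note shows. Statements on the series, on what has been measured and on what is new or still open speak of the compounds shown alone.

Measured in a functional assay on MCF7 cells (Homo sapiens) for inhibition, read by fluorescence, with a stated time of 72 h; a higher number here means a weaker inhibitor of growth, a lower number a stronger inhibitor of growth:
- compound 1 `CC(C)c1n[nH]c2c(NCc3ccccc3N)nc(NC[C@@H](C)O)nc12`: 4400 nM
- compound 2 `CC[C@@H](CO)Nc1nc(NCc2ccccc2N)c2[nH]nc(C(C)C)c2n1`: 10900 nM
- compound 3 `CC[C@H](CO)Nc1nc(NCc2ccccc2N)c2[nH]nc(C(C)C)c2n1`: not yet measured

Of the two measured compounds, compound 2 has the higher number, so it is the weaker inhibitor of growth. Compound 3 keeps the same atoms and bonds as compound 2, and only its drawn configuration differs: the two compounds have the same atoms and bonds and differ only in configuration as drawn: 1 of 1 stereo elements differ; a stereocentre at a saturated chain carbon is drawn S in compound 2 and R in compound 3.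

Within the data shown here, no measured step shows a change of configuration alone. Among the measured compounds shown here, the one available step swaps 2-hydroxypropyl for 1-(hydroxymethyl)propyl, so it is only a loose guide to size: a 2.5-fold higher number from compound 1 to compound 2 (0.39 log units; beyond the scatter). In this assay, a smaller step than that is expected, leaning tentatively towards a lower number. The estimated step is a 1.7-fold lower number from compound 2 to compound 3 (0.22 log units; within the scatter). For compound 3 the expected value is 6500 nM, with an estimated range of 2500 nM to 16000 nM.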

Compound 3, concentration for 50% growth inhibition: 2800 nM
The estimate for compound 3 lay 2.3-fold (0.37 log units) above the measured number; measured number inside the range.
By their numbers in this assay, from the lowest: compounds 3 and 1 (each within the scatter of the next); then compound 2.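

In this assay, the 1-(hydroxymethyl)propyl chain behaves differently depending on how its stereocentre is drawn, with a 3.9-fold lower number from compound 2 to compound 3 (0.59 log units; beyond the scatter). This is the first step shown that changes configuration alone, and the gap can be traced to the stereocentre because nothing else separates the pair: the fact that compounds 2 and 3 differ only in the configuration as drawn. The swap of 2-hydroxypropyl for 1-(hydroxymethyl)propyl also reads differently now, since the R form gives a 1.6-fold lower number from compound 1 to compound 3 (0.20 log units; within the scatter), so the earlier rise in the number belongs to the S form and not to the chain as such.

On these data alone, it remains open whether the R form would keep its edge on a longer chain, such as 1-(hydroxymethyl)butyl. As far as these compounds go, it is equally open what would happen with an amine in place of the chain's hydroxyl group.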